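This account rests on a few compounds, and the source may have more. Where it says the series, first, only, none or still open, it means among the compounds named here.

Compound 1 `[O-]/[N+](=C\c1cn(-c2ccccc2)nn1)c1ccccc1` is the parent of this small set. In a functional assay on MDA-MB-231 cells (Homo sapiens) for inhibition, read by MTT assay, with a stated time of 24 h (a lower number here means a stronger inhibitor, a higher number a weaker inhibitor), compound 1 returns only a limit, > 100000 nM. Its fluoro analogue compound 2 `[O-]/[N+](=C\c1cn(-c2ccc(F)cc2)nn1)c1ccccc1` gives 9800 nM in this assay. Going by the values given here, the step of an at least 10-fold lower number from compound 1 to compound 2 (1.00 log units; beyond the scatter) is the single measured comparison, and it rests on the limit of > 100000 nM in this assay, at which 1 of the 2 values shown sits, for compound 1. Compound 3 `[O-]/[N+](=C\c1cn(-c2ccc(Cl)cc2)nn1)c1ccccc1` carries the change (chloro in place of hydrogen on an aromatic carbon). Because the measured step of an at least 10-fold lower number from compound 1 to compound 2 (1.00 log units; beyond the scatter) was at least modest, a step of similar size toward a lower number is expected for an at least 16-fold lower number from compound 1 to compound 3 (1.22 log units; beyond the scatter). Compound 3 is therefore estimated at 6000 nM, with a range from 1500 nM to 40000 nM.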

Compound 3, half-maximal inhibitory concentration: 8900 nM
Estimate against measurement, compound 3: 1.5-fold (0.17 log units) below; the measured number falls inside the stated range.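

On the six-membered aromatic ring, para to a large group, chloro also departs from hydrogen in this assay, with an at least 11-fold lower number from compound 1 to compound 3 (1.05 log units; beyond the scatter), so the drop is not confined to fluoro. The two halogens cannot be told apart, with a 1.1-fold lower number from compound 2 to compound 3 (0.04 log units; within the scatter). The true size of the step from hydrogen remains unknown, as compound 1 gives only a limit: the limit of > 100000 nM in this assay, at which 1 of the 3 values shown sits.

The compounds shown leave open whether a group other than a halogen at this position, such as an amine or a carboxylic acid, would give a number like those of compound 2 and compound 3.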